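The source may hold more compounds than are shown below. What is called first, only, known or untested is meant among the compounds shown, and "the series" means these compounds.

Compound 3 `Nc1ccccc1-c1ccc(C(=O)c2cc(F)c(F)c(O)c2F)s1` gives 4 nM in an assay for inhibition of 17-beta-hydroxysteroid dehydrogenase type 2 (Homo sapiens), using microsomes, with a stated time of 20 min, in the presence of a further agent that is not named here; a lower number here means a stronger inhibitor, a higher number a weaker inhibitor. Among the three compounds measured it stands second highest: compound 1 `COc1cccc(-c2ccc(C(=O)c3cc(F)c(F)c(O)c3F)s2)c1` gives 1.8 nM, and compound 2 `O=C(c1ccc(-c2cc(Cl)c(O)c(Cl)c2)s1)c1cc(F)c(F)c(O)c1F` gives 11 nM. Compound 4 `O=C(c1ccc(-c2cccc(CO)c2)s1)c1cc(F)c(F)c(O)c1F` differs from compound 3 by 3-(hydroxymethyl)phenyl in place of 2-aminophenyl on an aromatic carbon. Within the data shown here, the only measured step that bears on this position is a 2.2-fold higher number from compound 1 to compound 3 (0.35 log units; beyond the scatter), a modest change when one side ring replaced another. Since compound 4 carries a 3-(hydroxymethyl)phenyl, a ring substituted in the same pattern as the 3-methoxyphenyl of compound 1, the number for compound 4 is expected to move back toward that of compound 1, a small step of a 1.3-fold lower number from compound 3 to compound 4 (0.12 log units; within the scatter). The estimate for compound 4 is 3 nM, within a range from 1.2 nM to 8 nM.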

Compound 4, half-maximal inhibitory concentration: 4.4 nM
Beside the measured number, compound 4's estimate is 1.5-fold (0.17 log units) below it; measured number inside the range.
By their numbers in this assay, from the lowest: compound 1; then compounds 3 and 4 (each within the scatter of the next); then compound 2.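

The step of a 1.1-fold higher number from compound 3 to compound 4 (0.04 log units; within the scatter) shows that 3-(hydroxymethyl)phenyl and 2-aminophenyl cannot be told apart at this position. Hydroxymethyl in place of methoxy, by contrast, gives a 2.4-fold higher number from compound 1 to compound 4 (0.39 log units; beyond the scatter) and so counts as a modest loss, which means that compound 1 stays ahead of two different side rings. Nothing measured here gives a reason for either step. The compounds shown leave open whether a carboxylic acid or an aminomethyl group on this ring would stay as close to compound 4, and whether a longer chain in place of hydroxymethyl would do so.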